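Swapping Chloro for Fluoro: Expected Effect on Stability

The source may report more compounds than this note shows. Statements on the series, on what has been measured and on what is new or still open speak of the compounds shown alone.

Three compounds have been examined in an ADME assay (liver) for metabolic stability, with Liver microsome (Rattus norvegicus) as the target, read by LC-MS, using microsomes and NADPH, with stated times of 5 min and 60 min, tested at 4 uM; a higher number here means that more of the compound is left, a lower number that less of the compound is left. Compound 1 `COc1cc(C(=O)O)ccc1OCCCCOc1ccc(C(=O)CC(C)(C)C)c(O)c1C` gives 49%, compound 2 `Cc1c(OCCCCOc2ccc(C(=O)O)cc2Cl)ccc(C(=O)CC2CCCC2)c1O` gives 21%, and compound 3 `CCCC(=O)c1ccc(OCCCCOc2cc(C(=O)O)ccc2OC)c(C)c1O` gives 1%. Among these, compound 2 holds the second highest number. Its gap to compound 3 and its larger gap to compound 1 both lie beyond the usual scatter. Compound 4 `Cc1c(OCCCCOc2ccc(C(=O)O)cc2F)ccc(C(=O)CC2CCCC2)c1O` has not yet been measured. It differs from compound 2 in one place, (fluoro in place of chloro on an aromatic carbon), so a fluoro takes the place of the chloro on the aromatic carbon. For the measured compounds named here, no measured pair shows this exchange, so nothing calibrates it. The step is expected to be a number 1 percentage points lower from compound 2 to compound 4 (within the scatter), within the usual scatter. Compound 4 is therefore estimated at 20%, within a range from 6% to 42%.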

Compound 4, percent of the compound remaining: 66%
For compound 4 the middle estimate is 46 percentage points below the measured one; the whole stated range lies below it.
By their numbers in this assay, from the lowest: compound 3; then compound 2; then compound 1; then compound 4.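

In this assay, changing 4-carboxy-2-chlorophenyl to 4-carboxy-2-fluorophenyl gives a large step, a number 45 percentage points higher from compound 2 to compound 4 (beyond the scatter). For the compounds shown here, this shows that the amount of compound left can depend strongly on which halogen sits at this place, ortho to a large group and meta to a carboxy group, something no earlier pair could isolate. Nothing shown here accounts for the size of this step.

Going by these compounds, it remains open how a nitrile or a plain hydrogen at this place would compare with fluoro. On these data alone, it is also open whether the same exchange would give a similar step with a different chain on the ketone.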